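A few compounds are considered here, and "the series" means these few. Any claim that something is new, unique, unknown or untested is made for them only; others in the source may bear on it.

Measured so far in an in vitro ADME assay on microsomes from liver (Homo sapiens) for pharmacokinetics, read by LC-MS, with a stated time of 10 min, tested at 1 uM; a higher number here means faster removal of the compound, a lower number slower removal:
Compound 1 `CN1C[C@H](C(=O)Nc2ccc(C#N)cc2)[C@@H](c2ccc(/C=C/C(=O)Nc3ccccc3N)cc2)C1` gives 1 mL/min/kg 
Compound 2 `CN1C[C@H](C(=O)NC2CC2)[C@@H](c2ccc(/C=C/C(=O)Nc3ccccc3N)cc2)C1` gives 10 mL/min/kg 

Of this pair, compound 2 holds the higher number, so it is the one removed faster. The next compound to be tested, compound 3 `CN1C[C@H](C(=O)N2CCCCC2)[C@@H](c2ccc(/C=C/C(=O)Nc3ccccc3N)cc2)C1`, keeps the shared core and alters a single group. The change is piperidin-1-yl in place of cyclopropylamino on a carbonyl carbon and it puts piperidin-1-yl in place of cyclopropylamino on a carbonyl carbon.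

Going by the values given here, only one measured step bears on this swap. That step, a 10-fold higher number from compound 1 to compound 2 (1.00 log units; beyond the scatter), is modest but beyond the scatter, and it comes from a change on the same amide group. It shows that a swap at this amide can move the number. Yet it replaces a very different group, and a single pair gives little guide to direction here. The expected move is therefore small and leans slightly upward, and the estimated step is a 1.4-fold higher number from compound 2 to compound 3 (0.15 log units; within the scatter) with wide margins. For compound 3 the estimated clearance is 14 mL/min/kg and it is expected to lie between 4 mL/min/kg and 40 mL/min/kg in most repeat measurements.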

Compound 3, clearance: 9 mL/min/kg
Estimate against measurement, compound 3: 1.6-fold (0.19 log units) above; measured number inside the range.
By their numbers in this assay, from the lowest: compound 1; then compounds 3 and 2 (each within the scatter of the next).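

In this assay, piperidin-1-yl in place of cyclopropylamino on the carbonyl carbon gives a 1.1-fold lower number from compound 2 to compound 3 (0.05 log units; within the scatter), so this swap, which enlarges the ring, adds heavy atoms and takes away the hydrogen-bond donor of the group, leaves the number within the scatter. The third compound also gives compound 1 a second comparison, a 9.0-fold higher number from compound 1 to compound 3 (0.95 log units; beyond the scatter), which lies beyond the scatter and sits close in size to a 10-fold higher number from compound 1 to compound 2 (1.00 log units; beyond the scatter), so among these three compounds the (4-cyanophenyl)amino group alone stands apart, while the two groups with non-aromatic rings do not separate from each other. No measurement shown here explains this result.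

Going by these compounds, it remains open whether the low number of compound 1 goes with its aromatic ring or with the nitrile on that ring, and a plain phenylamino group on the same carbonyl carbon would separate the two. On these data alone, it is also open whether an open-chain group such as dimethylamino would give a number like those of compound 2 and compound 3.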